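The source may report more compounds than this note shows. Statements on the series, on what has been measured and on what is new or still open speak of the compounds shown alone.

In an ADME assay on microsomes from liver (Homo sapiens) for metabolic stability, read by LC-MS, with a stated time of 10 min (a lower number here means that less of the compound is left, a higher number that more of the compound is left), compound 1 `CCCN(C[C@H]1Cc2c(cccc2N2CCNCC2)CN1)[C@H]1CCCc2cccnc21` gives 100% and compound 2 `C[C@@H]1CN(c2cccc3c2C[C@H](CN(C)[C@H]2CCCc4cccnc42)NC3)C[C@H](C)N1` gives 100%; compound 3 `CN1CCN(c2cccc3c2C[C@H](CN(C)[C@H]2CCCc4cccnc42)N(C)C3)CC1` gives 83.3%. Compound 2 thus stands level with compound 1 at the digits shown, the two together the highest of the three numbers, while compound 3 sits lower by a gap beyond the usual scatter. Compound 4 `CN(C[C@H]1Cc2c(cccc2N2CCNC(C)(C)C2)CN1)[C@H]1CCCc2cccnc21` is built from compound 2 by one change, (3,3-dimethylpiperazin-1-yl in place of 3,5-dimethylpiperazin-1-yl on an aromatic carbon). Among the compounds with values here, no measured pair in this set shows the effect of that change on its own, so only the position of compound 2 guides the outlook. The step from compound 2 to compound 4 in this assay is expected to be small, a number 8 percentage points lower from compound 2 to compound 4 (within the scatter), with no clear direction beyond the scatter. Compound 4 is estimated to give 92%, between 75% and 100%.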

Compound 4, percent of the compound remaining: 100%
Estimate against measurement, compound 4: 8 percentage points below; the measured number falls inside the stated range.
By their numbers in this assay, from the lowest: compound 3; then compounds 1, 2 and 4 (each within the scatter of the next).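

Within the data shown here, with 3,3-dimethylpiperazin-1-yl in place of 3,5-dimethylpiperazin-1-yl on the aromatic carbon, this assay shows no change at the digits printed from compound 2 to compound 4 (within the scatter) as the first direct reading of a change at this position. In this pair, the read-out therefore stays level without the two defined stereocentres of the 3,5-dimethylpiperazin-1-yl group. No measurement shown here offers an explanation for this result. The compounds shown leave open whether a morpholine on this aromatic carbon would stay level with compound 2 in this assay. They also leave open whether an open-chain amine there would do so.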